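This account rests on a few compounds, and the source may have more. Where it says the series, first, only, none or still open, it means among the compounds named here.

Among the compounds with values here, in an ADME assay on MT4 cells (Homo sapiens) for cytotoxicity, read by MTT assay, with a stated time of 96 h (on this read-out higher numbers stand for lower toxicity in this test and lower numbers for higher toxicity in this test), compound 1 (`COc1ccc(/N=N/N2CCCC2)cc1`) gives 68000 nM, the only true number so far. Compound 2 (`Fc1ccc(F)c(/N=N/N2CCCC2)c1`) gives > 100000 nM, which is a limit of the assay and not a number. Compound 3 (`O=[N+]([O-])c1ccc(/N=N/N2CCCC2)cc1`) has nitro in place of methoxy on an aromatic carbon, para to a group of 7 heavy atoms: nitro in place of methoxy on an aromatic carbon. Within the data shown here, no measured step bears on this change. The expected 1.2-fold lower number from compound 1 to compound 3 (0.09 log units; within the scatter) in this assay is none beyond the scatter. Compound 3 is estimated at 55000 nM, with an expected range of 18000 nM to 100000 nM.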

Compound 3, half-maximal cytotoxic concentration: >= 100000 nM
Compound 3 ended at the assay's limit; the forecaster's own chance of this, stated with the estimate: 30%; middle value at least 1.8-fold (0.25 log units) from the limit.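

In this assay, within the data shown here, nitro in place of methoxy on an aromatic carbon, para to a group of 7 heavy atoms, gives an at least 1.4-fold higher number from compound 1 to compound 3 (0.16 log units; that floor lies within the scatter) as the first one-place comparison. The floor of this step does not establish a change beyond the scatter, and the full size of the change cannot be read. The value of compound 3 is a limit and not a number: the limit of >= 100000 nM in this assay, at which 1 of the 3 values shown sits.

On these data alone, only methoxy and nitro are compared at this position, so the true value of compound 3 remains open. Also open, as far as these compounds go, is how an amine, a carboxylic acid or a longer chain at this place would read.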